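Replacing the aromatic group of inactive compound 3

This account rests on a few compounds, and the source may have more. Where it says the series, first, only, none or still open, it means among the compounds named here.

In a functional assay on A549 cells (Homo sapiens) for antiproliferative activity, read by MTT assay (a higher number here means a weaker inhibitor, a lower number a stronger inhibitor), compound 3 `Cc1c(-n2cc(COc3ccc(/C=C/C(=O)c4ccc5c(c4O)CCC(C)(C)O5)cc3)nn2)cccc1[N+](=O)[O-]` is reported as "not active" (no number reported), so it offers no number to step from. Compound 4 `Cc1ccc(-n2cc(COc3ccc(/C=C/C(=O)c4ccc5c(c4O)CCC(C)(C)O5)cc3)nn2)cc1Br` keeps the same core but carries 3-bromo-4-methylphenyl in place of 2-methyl-3-nitrophenyl on an aromatic nitrogen. Among the measured compounds shown here, the only measured guide comes from a different core, where compound 1 `CC(=O)c1ccc(-n2cc(COc3ccc(/C=C/C(=O)c4cc5c(cc4O)OC(C)(C)CC5)cc3)nn2)cc1` gives 66300 nM and compound 2 `CCc1ccccc1-n1cc(COc2ccc(/C=C/C(=O)c3cc4c(cc3O)OC(C)(C)CC4)cc2)nn1` gives 137000 nM. That exchange on the same aromatic nitrogen is a 2.1-fold higher number from compound 1 to compound 2 (0.32 log units; beyond the scatter), a modest step. No step size can be stated from compound 3, but compound 4 is expected to remain a weak inhibitor, if it gives a number at all. Compound 4 is estimated at 100000 nM, with an expected range of 35000 nM to 280000 nM.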

Compound 4, half-maximal inhibitory concentration: "not active" (no number reported)
Nothing numeric was reported for compound 4, so the estimate cannot be set against anything.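

In this assay compound 3 and compound 4 are both reported as "not active", so no step can be read between them. Nothing shown explains this result. On these data alone, whether any aromatic group at this place gives a number on their shared core stays open.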